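The source may hold more compounds than are shown below. What is called first, only, known or untested is meant among the compounds shown, and "the series" means these compounds.

In a functional assay on K-562R cells (Homo sapiens) for cytotoxicity, read by MTT assay, with a stated time of 48 h (on this read-out higher numbers stand for weaker inhibition and lower numbers for stronger inhibition), compound 1 (`COc1cc(-n2c(-c3ccc(O)cc3)c[nH]c2=O)cc(OC)c1OC`) gives > 50000 nM, which is a limit of the assay and not a number. Compound 2 (`COc1ccc(-c2c[nH]c(=O)n2-c2cc(OC)c(OC)c(OC)c2)cc1[N+](=O)[O-]`) gives > 50000 nM in this assay, and this too is only a limit. Compound 2 therefore has no numerical value to stand on, and the one other result beside it is also a limit. The record so far amounts to the limit of > 50000 nM in this assay, at which 2 of the 2 values shown sit.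

The next compound, compound 3 (`COc1ccc(-c2c[nH]c(=O)n2-c2cc(OC)c(OC)c(OC)c2)cc1N`), keeps the shared core of compound 2 and has amino in place of nitro on an aromatic carbon, ortho to a methoxy group and meta to a large group: amino in place of nitro on an aromatic carbon.

Within the data shown here, no measured pair yet shows what a change at this place does in this assay, so any expectation here is loose. A move toward stronger inhibition is expected, though a further limit remains quite possible. The expected size is an at least 10-fold lower number from compound 2 to compound 3 (1.00 log units; beyond the scatter). For compound 3 the estimated value is 5000 nM, with an expected range from 100 nM to 50000 nM.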

Compound 3, half-maximal inhibitory concentration: > 50000 nM
Compound 3 was reported as a limit (the forecaster's own chance of this, stated with the estimate: 35%); middle value at least 10-fold (1.00 log units) away from the limit.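

Compound 3 gives > 50000 nM in this assay, which is a limit and not a number. Neither step to compound 3, from compound 1 or from compound 2, can be read, and the record stands at a single limit: the limit of > 50000 nM in this assay, at which 3 of the 3 values shown sit. The compounds shown leave open whether any change at this place yields a measurable value in this assay.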